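Working notes: replacing the group on the amine nitrogen

This account rests on a few compounds, and the source may have more. Where it says the series, first, only, none or still open, it means among the compounds named here.

- Compound 1 `O=[N+]([O-])c1cccc(NC(=S)NCCNS(=O)(=O)c2ccc(-c3ccccc3OCc3ccccc3)s2)c1` gives 18300 nM
- Compound 2 `O=[N+]([O-])c1cccc(NC(=S)NCCNS(=O)(=O)c2ccc(-c3ccccc3OCc3cccc(O)c3)s2)c1` gives 13800 nM

In an ADME assay on HEK-293T cells (Homo sapiens) for cytotoxicity, read by CCK-8 assay, with a stated time of 48 h (on this read-out higher numbers stand for weaker inhibition and lower numbers for stronger inhibition), compound 2 stands within the scatter of compound 1, so the two measured compounds cannot be ranked. Compound 3 `COc1ccc(NC(=O)NCCNS(=O)(=O)c2ccc(-c3ccccc3OCc3cccc(O)c3)s2)cc1` keeps the core of compound 2 and changes the group on an amine nitrogen, where (4-methoxyphenyl)carbamoyl enters: a group of 11 heavy atoms (8 carbon, 1 nitrogen, 2 oxygen; one six-membered aromatic ring of carbon only) in place of a group of 12 heavy atoms (7 carbon, 2 nitrogen, 2 oxygen, 1 sulfur; one six-membered aromatic ring of carbon only), on an amine nitrogen. Among the compounds with values here, the only measured step is a 1.3-fold lower number from compound 1 to compound 2 (0.12 log units; within the scatter), for hydroxy in place of hydrogen on an aromatic carbon. Within the data shown here, that step lies elsewhere in the molecule, so it shows only that this one change left this assay within the scatter. Among the measured compounds shown here, no measured step covers the exchange on the amine nitrogen, and the size of the coming step is therefore poorly constrained. For the measured compounds named here, no step clearly beyond the scatter is expected, with a slight lean toward a higher number that rests on judgment and not on a measured step. The expected step is a 1.8-fold higher number from compound 2 to compound 3 (0.26 log units; within the scatter). The estimated value for compound 3 is 25000 nM, with an expected range from 10000 nM to 60000 nM.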

Compound 3, half-maximal inhibitory concentration: > 20000 nM
Compound 3: no number, only a limit; the forecaster's own chance of this, stated with the estimate: 15%; the middle value lies beyond the limit too.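

In this assay compound 3 carries a limit and not a number: the limit of > 20000 nM in this assay, at which 1 of the 3 values shown sits.

Read as a floor, the exchange of the 12-heavy-atom group for (4-methoxyphenyl)carbamoyl on the amine nitrogen gives an at least 1.4-fold higher number from compound 2 to compound 3 (0.16 log units; that floor lies within the scatter), so the true size of this step remains unfixed. Within the data shown here, this is the first reading at this position, and it gives no sign of a lower number on this exchange, which the hydroxy step elsewhere in the molecule could not show.

On these data alone, whether the step from compound 2 to compound 3 truly lies beyond the scatter stays open, and the exchange alters the whole group at once, so the share of the sulfur-bearing part that leaves cannot be separated from that of the methoxy-bearing ring that enters. As far as these compounds go, how a smaller group on the same amine nitrogen, such as acetyl, or a group bearing a carboxylic acid or a basic amine, would read in this assay also remains open.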